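Swapping a Cyano Group for an Acetamido Group

The source may hold more compounds than are shown below. What is called first, only, known or untested is meant among the compounds shown, and "the series" means these compounds.

In a functional assay on HepG2 cells (Homo sapiens) for cytotoxicity, read by MTT assay, with a stated time of 24 h (on this read-out higher numbers stand for weaker inhibition and lower numbers for stronger inhibition), compound 3 `N#Cc1ccc(S(=O)(=O)N2C/C(=C\c3ccncc3)C(=O)/C(=C/c3ccccc3F)C2)cc1` gives 4500 nM. Compound 1 `CC(=O)Nc1ccc(S(=O)(=O)N2C/C(=C\c3cccnc3)C(=O)/C(=C/c3ccccc3F)C2)cc1` gives 4560 nM, which lies within the usual scatter of the value for compound 3, so these two cannot be told apart. Compound 2 `O=C1/C(=C/c2ccncc2)CN(S(=O)(=O)c2ccc(Br)cc2)C/C1=C\c1ccccc1F` gives 9300 nM, a clearly higher number.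

The next case is compound 4 `CC(=O)Nc1ccc(S(=O)(=O)N2C/C(=C\c3ccncc3)C(=O)/C(=C/c3ccccc3F)C2)cc1`. Its change from compound 3 is acetamido in place of cyano on an aromatic carbon, para to a large group (acetamido in place of cyano on an aromatic carbon).

Going by the values given here, only one measured step touches this same place: a 2.1-fold lower number from compound 2 to compound 3 (0.32 log units; beyond the scatter). This modest step, with cyano in place of bromo, lies just beyond the scatter. It involves a different pair of groups, however, so it offers only a rough sense of how far such a swap can move the number. The exchange of cyano for acetamido itself has not been measured directly. Compound 1, which also carries an acetamido group, gives 4560 nM, and that value supports expecting little movement.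

No step beyond the scatter is therefore expected in this assay, and the estimate is a 1.1-fold higher number from compound 3 to compound 4 (0.03 log units; within the scatter). For compound 4 the expected value is 4800 nM, with an estimated range from 2400 nM to 9500 nM.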

Compound 4, half-maximal inhibitory concentration: 11700 nM
For compound 4 the middle estimate is 2.4-fold (0.39 log units) below the measured one; measured number above the stated range.
By their numbers in this assay, from the lowest: compounds 3 and 1 (each within the scatter of the next); then compounds 2 and 4 (each within the scatter of the next).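

At this position the choice of group matters in this assay: acetamido does not behave like cyano on this aromatic carbon (a 2.6-fold higher number from compound 3 to compound 4 (0.41 log units; beyond the scatter)), even though the two groups differ by only a few heavy atoms. Acetamido and bromo, by contrast, cannot be told apart here (a 1.3-fold higher number from compound 2 to compound 4 (0.10 log units; within the scatter)), so among the three compounds that carry pyridin-4-yl, cyano alone stands apart with the lowest number. The value of an acetamido group also proves to depend on the rest of the molecule, since moving from pyridin-3-yl to pyridin-4-yl with acetamido held fixed shifts the number by about as much (a 2.6-fold higher number from compound 1 to compound 4 (0.41 log units; beyond the scatter)), and a result from one of these two pyridine series therefore cannot simply be carried over to the other.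

No measurement at hand explains why the number moves in either of these steps. Still open, going by these compounds, is where an amine or a carboxylic acid on the same aromatic carbon would fall, and whether cyano paired with pyridin-3-yl would keep the low number seen with pyridin-4-yl.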